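Cytotoxicity check on a difluoromethoxyphenyl ethyl analogue

This account rests on a few compounds, and the source may have more. Where it says the series, first, only, none or still open, it means among the compounds named here.

In a toxicity assay on MDCK cells (Canis lupus familiaris) for cytotoxicity, read by crystal violet staining, with a stated time of 48 h (on this read-out higher numbers stand for lower toxicity in this test and lower numbers for higher toxicity in this test), compound 1 `CCc1ccc2[nH]c(=O)c(CN(Cc3ccc(OCOC)cc3)Cc3ccc(C(C)(C)C)cc3)cc2c1` gives > 10000 nM, which is a limit of the assay. Compound 2 `CCc1ccc2[nH]c(=O)c(CN(Cc3ccc(C(C)(C)C)cc3)[C@H](C)c3ccc(F)cc3)cc2c1` gives > 5000 nM in this assay, also a limit. Both values sit at limits, the limit of > 10000 nM in this assay, at which 1 of the 2 values shown sits, and (the limit of > 5000 nM in this assay, at which 1 of the 2 values shown sits), so the step that the two limits leave unreadable from compound 1 to compound 2 is not readable. Compound 3 `CCc1ccc2[nH]c(=O)c(CN(Cc3ccc(C(C)(C)C)cc3)C(C)c3ccc(OC(F)F)cc3)cc2c1` differs from compound 2 by 1-(4-(difluoromethoxy)phenyl)ethyl in place of 1-(4-fluorophenyl)ethyl on an amine nitrogen. No readable measured step bears on this change, so no shift beyond the scatter is expected. The expected step that the limit leaves unreadable from compound 2 to compound 3 is flat. Compound 3 is estimated at 10000 nM, with a range from 3000 nM to 30000 nM, most likely reported again as a limit.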

Compound 3, half-maximal cytotoxic concentration: > 5000 nM
Compound 3 ended at the assay's limit (the forecaster's own chance of this, stated with the estimate: 80%); the middle value is on the limit's open side.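

For the compounds shown here, compound 1, compound 2 and compound 3 all sit at limits of the assay, so no step among them can be read. As far as these compounds go, whether any of these amine nitrogen changes shifts the half-maximal cytotoxic concentration remains open.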